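Turning the Linker Around: From Compound 3 to Compound 4

The source may report more compounds than this note shows. Statements on the series, on what has been measured and on what is new or still open speak of the compounds shown alone.

Measured in a functional assay on MDA-MB-231 cells (Homo sapiens) for cytotoxicity, read by MTT assay, with a stated time of 72 h; on this read-out higher numbers stand for weaker inhibition and lower numbers for stronger inhibition:
- compound 1 `COc1cc2c(Oc3ccc(NC(=O)N/N=C/c4ccncc4)cc3F)ccnc2cc1OCCCN1CCCCC1`: 1400 nM
- compound 2 `COc1cc2c(Oc3ccc(NC(=O)N/N=C/c4cccs4)cc3F)ccnc2cc1OCCCN1CCCCC1`: 1260 nM
- compound 3 `COc1cc2c(Oc3ccc(NC(=S)N/N=C/c4ccccc4)cc3F)ccnc2cc1OCCCN1CCCCC1`: 1200 nM

The three measured compounds share one core and differ only in the chain hanging from the nitrogen on the fluorinated ring. In this assay their numbers sit close together: the step of a 1.1-fold lower number from compound 1 to compound 2 (0.05 log units; within the scatter) and the step of a 1.2-fold lower number from compound 1 to compound 3 (0.07 log units; within the scatter) are both small, as is a 1.1-fold lower number from compound 2 to compound 3 (0.02 log units; within the scatter). Compound 3 thus gives a number that cannot be told apart from those of compound 1 and compound 2.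

Compound 4 `COc1cc2c(Oc3ccc(/C=N/NC(=O)Nc4ccccc4)cc3F)ccnc2cc1OCCCN1CCCCC1` carries the change (a group of 12 heavy atoms (8 carbon, 3 nitrogen, 1 oxygen; one six-membered aromatic ring of carbon only) in place of a group of 12 heavy atoms (8 carbon, 3 nitrogen, 1 sulfur; one six-membered aromatic ring of carbon only), on an aromatic carbon). The attachment is reversed: the hydrazone carbon now sits on the fluorinated ring and the phenyl ring sits on the urea nitrogen, while a carbonyl replaces the thione. For the measured compounds named here, none of the measured steps reverses the linker; the nearest is the sulfur-for-oxygen exchange folded into the step from compound 1 to compound 3, which stayed within the scatter. As far as these compounds go, with every measured change leaving the number essentially unmoved, no step beyond the scatter is expected for compound 4, and a 1.1-fold higher number from compound 3 to compound 4 (0.03 log units; within the scatter) is the estimated outcome, with wide uncertainty since the reversal itself is untested. Compound 4 is therefore expected to give about 1300 nM, within 450 nM to 3800 nM.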

Compound 4, half-maximal inhibitory concentration: 1200 nM
For compound 4 the middle estimate is 1.1-fold (0.03 log units) above the measured one; measured number inside the range.
By their numbers in this assay, from the lowest: compounds 3, 4, 2 and 1 (each within the scatter of the next).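

In this assay, the reversed linker on the aromatic carbon para to a large group, with a carbonyl in place of the thione, gives no change at the digits printed from compound 3 to compound 4 (within the scatter), so even this rearrangement of the chain, much larger than the ring exchanges seen earlier, leaves the read-out where it was. The comparisons with the other two compounds agree, with a 1.1-fold lower number from compound 2 to compound 4 (0.02 log units; within the scatter) and a 1.2-fold lower number from compound 1 to compound 4 (0.07 log units; within the scatter), so all four compounds, in either orientation of the linker, remain within the scatter of one another in this assay. No accompanying data bear on why the numbers stay together here.

Because the step from compound 3 to compound 4 combines the reversal with the exchange of thione for carbonyl, the compounds shown cannot separate the contribution of each, and a single flat result could also conceal two opposing contributions. As far as these compounds go, it also remains open whether any group on the phenyl ring of the reversed chain, such as a carboxylic acid or a dimethylamino group, or a longer chain in place of the hydrazone link, would move the number beyond the scatter.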